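The source may report more compounds than this note shows. Statements on the series, on what has been measured and on what is new or still open speak of the compounds shown alone.

Working notes on the series in a functional assay on the whole organism for antagonist activity, with Mus musculus as the target; a higher number here means that more compound is needed for the effect, a lower number that less compound is needed. Within the data shown here, compound 3 `COc1ccc(CN2CCC(C(=O)Nc3cc(Cl)c(N)cc3OC)CC2)cc1` is the only member of the set with a number rather than a limit in this assay: compound 3 gives 0.9 mg/kg. Compound 1 `COc1cc(N)c(Cl)cc1NC(=O)C1CCN(Cc2ccccc2Cl)CC1` reaches only a limit in this assay, compound 1 giving > 4 mg/kg. Compound 2 `CCCN1CCC(C(=O)Nc2cc(Cl)c(N)cc2OC)CC1` likewise stops at a limit, compound 2 giving > 10 mg/kg. The steps of an at least 4.4-fold lower number from compound 1 to compound 3 (0.64 log units; beyond the scatter) and an at least 11-fold lower number from compound 2 to compound 3 (1.04 log units; beyond the scatter) both lead to the 4-methoxyphenyl of compound 3, while the step that the two limits leave unreadable from compound 1 to compound 2 cannot be read between the two limits.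

Compound 4 `COc1cc(N)c(Cl)cc1NC(=O)C1CCN(Cc2ccc(OCc3ccccc3)cc2)CC1` differs from compound 3 by phenyl in place of hydrogen on a saturated chain carbon bound to an oxygen on an aromatic ring, so methoxy becomes benzyloxy. Among the measured compounds shown here, no measured step touches this position: the readable steps all exchange the group on the saturated chain carbon bound to the amine nitrogen in the ring, and show only that the aryl group there carries the measurable activity. For the measured compounds named here, there is no precedent in the set for enlarging the methoxy, so the expected step from compound 3 to compound 4 is a small one, a 2.2-fold higher number from compound 3 to compound 4 (0.35 log units; beyond the scatter), with a loss held more likely than a gain. Compound 4 is estimated at 2 mg/kg, expected between 0.6 mg/kg and 8 mg/kg.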

Compound 4, dose for half-maximal effect: > 4 mg/kg
Compound 4 was reported as a limit (the forecaster's own chance of this, stated with the estimate: 25%); middle value at least 2.0-fold (0.30 log units) away from the limit.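

Among these compounds, this is the first readable change at this position, on a saturated chain carbon bound to an oxygen on an aromatic ring: in this assay, going from methoxy to benzyloxy gives an at least 4.4-fold higher number from compound 3 to compound 4 (0.64 log units; beyond the scatter). The earlier steps shown here exchanged only the group on the saturated chain carbon bound to the amine nitrogen in the ring, so they showed that the 4-methoxyphenyl there gives a number; this step shows that the number does not tolerate every enlargement of the methoxy, since the added phenyl moves the result beyond the scatter towards more compound needed. Compound 4 gives > 4 mg/kg, which is a limit and not a number, so the full size of the loss cannot be read, and the value is one of a pair sitting at that limit: the limit of > 4 mg/kg in this assay, at which 2 of the 4 values shown sit.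

Open, on these data alone, is whether the loss belongs to the phenyl itself or to any growth at this oxygen, which an ethyl or a longer chain in place of the methyl would separate. Also open, as far as these compounds go, is whether a hydroxyl in place of the methoxy, or an amine or a carboxylic acid on the added phenyl, would return a number in this assay.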